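Aryl swap on the ring nitrogen: compound 3 to compound 4

The source may report more compounds than this note shows. Statements on the series, on what has been measured and on what is new or still open speak of the compounds shown alone.

Three compounds of the series share one core and differ only in the aryl group carried on an aromatic nitrogen. In a functional assay on A549 cells (Homo sapiens) for antiproliferative activity, read by MTT assay, with a stated time of 48 h (a lower number here means a stronger inhibitor, a higher number a weaker inhibitor), compound 1 `N#CC1=C(N)Oc2c(N)cc3nc4ccccc4nc3c2C12C(=O)N(Cc1cnnn1-c1cccc(C(F)(F)F)c1)c1ccccc12` gives 5400 nM. Compound 2 `COc1ccccc1-n1nncc1CN1C(=O)C2(C(C#N)=C(N)Oc3c(N)cc4nc5ccccc5nc4c32)c2ccccc21` gives 37500 nM, and compound 3 `COc1ccc(OC)c(-n2nncc2CN2C(=O)C3(C(C#N)=C(N)Oc4c(N)cc5nc6ccccc6nc5c43)c3ccccc32)c1` gives 28100 nM. Compound 3 thus holds the second highest of the three numbers; its nearest neighbour is compound 2 (a 1.3-fold lower number from compound 2 to compound 3 (0.13 log units; within the scatter)), and its furthest is compound 1 (a 5.2-fold higher number from compound 1 to compound 3 (0.72 log units; beyond the scatter)).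

Compound 4 `N#CC1=C(N)Oc2c(N)cc3nc4ccccc4nc3c2C12C(=O)N(Cc1cnnn1-c1ccc(F)c(Cl)c1)c1ccccc12` is not yet measured. Its change from compound 3 is 3-chloro-4-fluorophenyl in place of 2,5-dimethoxyphenyl on an aromatic nitrogen. Going by the values given here, the steps that bear on this are the two that replaced the 3-(trifluoromethyl)phenyl of compound 1 by a methoxy-bearing aryl: a 6.9-fold higher number from compound 1 to compound 2 (0.84 log units; beyond the scatter) and a 5.2-fold higher number from compound 1 to compound 3 (0.72 log units; beyond the scatter). Both raised the number by a modest amount. Compound 4 moves back to an aryl without hydrogen-bond acceptors, as in compound 1, so a lower number is expected, though the halogen pattern is new to the series and the size is uncertain. The estimated step is a 3.1-fold lower number from compound 3 to compound 4 (0.49 log units; beyond the scatter). For compound 4 the expected value is 9000 nM, with a range from 3000 nM to 27000 nM.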

Compound 4, half-maximal inhibitory concentration: 43400 nM
Compound 4: middle estimate off by 4.8-fold (0.68 log units), on the low side; the whole stated range lies below it.
By their numbers in this assay, from the lowest: compound 1; then compounds 3, 2 and 4 (each within the scatter of the next).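

In this assay, the 3-chloro-4-fluorophenyl group of compound 4, with no hydrogen-bond acceptors, cannot be told apart from the methoxy-bearing aryl groups at this position (a 1.5-fold higher number from compound 3 to compound 4 (0.19 log units; within the scatter)) and (a 1.2-fold higher number from compound 2 to compound 4 (0.06 log units; within the scatter)). Compound 1 also carries an aryl group with no hydrogen-bond acceptors and a halogen, yet it remains clearly separate from compound 4 (an 8.0-fold higher number from compound 1 to compound 4 (0.91 log units; beyond the scatter)), so the absence of hydrogen-bond acceptors does not by itself go with a low number in this set. Among the four compounds, only the 3-(trifluoromethyl)phenyl group of compound 1 stands apart, and compound 4 goes against any reading that halogen-bearing aryl groups as a class give the lower number.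

No measurement at hand accounts for the gap between compound 1 and compound 4. The compounds shown leave open whether the lower number of compound 1 depends on the trifluoromethyl group itself or on its place on the aryl ring, and how an unsubstituted phenyl, or an aryl group carrying an amine or a carboxylic acid, would read at this position.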